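Extending a dimethylimidazole into a fused bicycle on the chloropyridine

The source may hold more compounds than are shown below. What is called first, only, known or untested is meant among the compounds shown, and "the series" means these compounds.

Of the compounds shown here, two built on the same core have been measured in a physicochemical assay for lipophilicity, using the shake flask method, measured as octanol-water partition, at pH 7.4; on this read-out higher numbers stand for higher lipophilicity and lower numbers for lower lipophilicity. Compound 1 `CC(=O)N[C@@H]1CCC[C@H](C(=O)Nc2cc(-c3cnc(C)n3C)c(Cl)cn2)C1` gives 2.2, the lowest of the two numbers. Compound 2 `CC(=O)N[C@@H]1CCC[C@H](C(=O)Nc2cc(-c3cnn4c3CC(C)(C)C4)ccn2)C1` gives 2.8, a value that lies beyond the scatter above compound 1. Going by the values given here, no pair among the measured compounds differs in only one place, so no single step can be read off directly.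

Compound 3 `CC(=O)N[C@@H]1CCC[C@H](C(=O)Nc2cc(-c3cnc4n3CC(C)(C)C4)c(Cl)cn2)C1` has not yet been measured. It departs from compound 1 in one place: a group of 10 heavy atoms (8 carbon, 2 nitrogen; one five-membered non-aromatic ring with 1 hetero atom, one five-membered aromatic ring with 2 hetero atoms) in place of a group of 7 heavy atoms (5 carbon, 2 nitrogen; one five-membered aromatic ring with 2 hetero atoms), on an aromatic carbon The chloro group and the rest of the core remain as in compound 1.

Since three additional carbon atoms join the ring system while the count of hydrogen-bond donors and acceptors stays the same, an increase is expected for the step from compound 1 to compound 3, of a size estimated at a number 0.80 log units higher from compound 1 to compound 3 (beyond the scatter), clearly beyond the scatter. This expectation is supported because compound 2, which also carries a bicyclic ring system, gives 2.8. Compound 3 is therefore estimated at 3, with a likely range from 2.6 to 3.5.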

Compound 3, distribution coefficient: 3.6
For compound 3 the middle estimate is 0.60 log units below the measured one; the measured number lies above the stated range.
By their numbers in this assay, from the lowest: compound 1; then compound 2; then compound 3.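

In this assay, going by these compounds alone, the exchange of the 1,2-dimethyl-1H-imidazol-5-yl group for the group with one five-membered non-aromatic ring and one five-membered aromatic ring gives a number 1.40 log units higher from compound 1 to compound 3 (beyond the scatter) and counts as a large step; it is the only single change that can be read here, on an aromatic carbon ortho to a chloro group and opposite the ring nitrogen. The step comes with no change in the counts of hydrogen-bond donors and acceptors and none in net charge, so at this position the read-out moved well beyond the scatter while those counts stayed the same, and the entering group differs from the leaving one in its added carbon atoms and its non-aromatic ring. Nothing measured alongside this result accounts for the size of the step.

Whether the same exchange would give a step of similar size without the chloro group cannot be read from the compounds shown. They also leave open how the number would respond at this aromatic carbon to a group carrying an amine, a carboxylic acid or a longer chain.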